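Removing a chloro from the biaryl ether, tolerance outlook

This account rests on a few compounds, and the source may have more. Where it says the series, first, only, none or still open, it means among the compounds named here.

Measured so far in a functional assay on MT4 cells (Homo sapiens) for cytotoxicity, read by MTT assay, with a stated time of 5 days; a higher number here means that more compound is tolerated, a lower number that less compound is tolerated:
compound 1, `N#Cc1ccc(Nc2nccc(Nc3ccc(-c4ccc(C#N)cc4)cc3F)n2)cc1`, gives 308000 nM.
compound 2, `N#Cc1ccc(Nc2nccc(Oc3ccc(-c4ccc(C#N)cc4Cl)cc3Cl)n2)cc1`, gives > 273000 nM.
compound 3, `Cc1cc(C#N)ccc1-c1ccc(Oc2ccnc(Nc3ccc(C#N)cc3)n2)c(F)c1`, gives > 296000 nM.

The value for compound 2 is a limit of this assay and not a number, the one described as the limit of > 273000 nM in this assay, at which 1 of the 3 values shown sits. The value for compound 3 is likewise a limit, the one described as the limit of > 296000 nM in this assay, at which 1 of the 3 values shown sits. Compound 1 alone gives a measured number in this assay, and it sits close to where the two limits lie. Compound 2 therefore stands among compounds whose tolerance could not be resolved by the assay.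

The unmeasured compound 4, `N#Cc1ccc(Nc2nccc(Oc3ccc(-c4ccc(C#N)cc4)cc3Cl)n2)cc1`, differs from compound 2 by hydrogen in place of chloro on an aromatic carbon. Within the data shown here, no comparable step between measured compounds is available here. Given that compound 2 already sits at a limit, the expected step from compound 2 to compound 4 is none beyond the scatter, a step that the limit leaves unreadable from compound 2 to compound 4, and compound 4 is estimated to be reported again near or at a limit. For compound 4 the estimate in this assay is 280000 nM, with a range from 140000 nM to 600000 nM.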

Compound 4, half-maximal cytotoxic concentration: > 295000 nM
Compound 4: no number, only a limit; the forecaster's own chance of this, stated with the estimate: 70%; at least 1.0-fold (0.02 log units) between middle value and limit.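

In this assay compound 4 gives > 295000 nM, a limit and not a number. Compound 2 also has only a limit, so no step can be read between compound 2 and compound 4. The compounds shown leave open whether replacing 2-chloro-4-cyanophenyl with 4-cyanophenyl changes tolerance at all.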